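Biaryl benzylamine series: nitro in place of methyl

The compounds below may be only part of what the source reports. "The series", "measured", "known", "first", "only" and "open" are said of these compounds alone.

Measured so far in an assay on HEK293 cells for displacement of a labelled ligand from C-X-C chemokine receptor type 3 (Homo sapiens); on this read-out higher numbers stand for weaker inhibition and lower numbers for stronger inhibition:
Compound 1, `CN(CC1=CC[C@H]2C[C@@H]1C2(C)C)Cc1ccc(Br)cc1`: compound 1 gives 3160 nM in this assay.
Compound 2, `COC(=O)c1cccc(-c2ccc(CN(C)CC3=CC[C@H]4C[C@@H]3C4(C)C)cc2)c1`: compound 2 is reported only as a limit of this assay, > 316 nM.
Compound 3, `Cc1cccc(-c2ccc(CN(C)CC3=CC[C@H]4C[C@@H]3C4(C)C)cc2)c1`: compound 3 is likewise reported only as a limit of this assay, > 316 nM.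

Compound 3 therefore stands at no number but at a limit, and it shares that position with one other value (the limit of > 316 nM in this assay, at which 2 of the 3 values shown sit). The two steps that lead to compound 3 are both unreadable: a step that the limit leaves unreadable from compound 1 to compound 3 and a step that the two limits leave unreadable from compound 2 to compound 3. Going by the values given here, compound 1 is the only member of the series with a number.

The unmeasured compound 4, `CN(CC1=CC[C@H]2C[C@@H]1C2(C)C)Cc1ccc(-c2cccc([N+](=O)[O-])c2)cc1`, differs from compound 3 by nitro in place of methyl on an aromatic carbon. Among the compounds with values here, none of the measured steps covers a nitro group, and the two steps into compound 3 give no size. Within the data shown here, the only anchor is that compound 3 sits at a limit, so the same limit is the most likely outcome for compound 4, with a number becoming readable only if the step is large.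

Estimate: compound 4 is expected at 1500 nM, with a range from 300 nM to 10000 nM. The step this estimate implies, a step that the limit leaves unreadable from compound 3 to compound 4, is expected to lie within the scatter.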

Compound 4, inhibition constant: 2000 nM
Beside the measured number, compound 4's estimate is 1.3-fold (0.12 log units) below it; the range from low to high includes it.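

In this assay, the 3-nitrophenyl group in place of bromo gives a 1.6-fold lower number from compound 1 to compound 4 (0.20 log units; within the scatter), so these two compounds cannot be told apart on this read-out. From the compounds shown here alone, two of the values remain limits of the assay rather than numbers, and the steps to compound 4 from the compounds at that limit cannot be read: the limit of > 316 nM in this assay, at which 2 of the 4 values shown sit A biaryl member now carries a number, which makes the 3-nitrophenyl group a reference for reading other groups at this place, while the size of nitro in place of methyl or methoxycarbonyl remains unknown.

Going by these compounds, it remains open whether an amine, a carboxylic acid or a nitrile at this place would shift the read-out beyond the scatter, and whether a plain phenyl would differ from the 3-nitrophenyl group. The compounds shown also leave open how much the read-out depends on the substituent's place on the outer aromatic ring, since only one place on that ring appears here.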